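A few compounds are considered here, and "the series" means these few. Any claim that something is new, unique, unknown or untested is made for them only; others in the source may bear on it.

Measured in a functional assay on the whole organism for inhibition, with Mus musculus as the target; a lower number here means that less compound is needed, a higher number that more compound is needed for the effect:
compound 1 `CC(C)C1(C)CCOC1=O`, 198 mg/kg
compound 2 `CC(C)C1(C(C)C)CCOC1=O`, 137 mg/kg
compound 3 `CC(C)C1(C)CCSC1=O`, 154 mg/kg

Compound 4 `CC(C)C1(C(C)C)CCSC1=O` is not yet measured. Relative to compound 3 it carries isopropyl in place of methyl on a saturated ring carbon. The same kind of change is seen between compound 1 and compound 2, namely (isopropyl in place of methyl on a saturated ring carbon); there the place is on a saturated ring carbon of a five-membered non-aromatic ring with 1 oxygen, two ring bonds from the ring oxygen, whereas in compound 4 the ring holds 1 sulfur, two ring bonds from the ring sulfur. The difference between the two cores is not broken down here. In this assay the measured step is a 1.4-fold lower number from compound 1 to compound 2 (0.16 log units; within the scatter). For compound 4 a step of similar size is expected, a 1.3-fold lower number from compound 3 to compound 4 (0.13 log units; within the scatter), resting on that single precedent and on compound 3 giving 154 mg/kg. Compound 4 is estimated at 115 mg/kg, expected between 70 mg/kg and 190 mg/kg.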

Compound 4, dose for half-maximal effect: > 500 mg/kg
Compound 4: only a limit was reported; the forecaster's own chance of this, stated with the estimate: 5%; middle value at least 4.3-fold (0.63 log units) away from the limit.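

In this assay, isopropyl in place of methyl on a saturated ring carbon gives an at least 3.2-fold higher number from compound 3 to compound 4 (0.51 log units; beyond the scatter), so on the core of compound 3 the change does not follow the earlier step. The result on one core does not carry over to the other: the same change on two cores in this assay, a 1.4-fold lower number (0.16 log units; within the scatter) from compound 1 to compound 2 and an at least 3.2-fold higher number (0.51 log units; beyond the scatter) from compound 3 to compound 4, at least 4.6-fold (0.67 log units) apart, beyond the scatter of two such steps
Compound 4 gives > 500 mg/kg, which is a limit of the assay and not a number, and a single pair on each core does not show how far the step extends or why the two cores part.

Open is where the turn sets in on the ring-sulfur core, since ethyl on that saturated ring carbon lies outside the compounds shown. Also open, going by these compounds, is whether a longer chain or an amine there would follow the core of compound 1 or the core of compound 3.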